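The compounds below may be only part of what the source reports. "The series", "measured", "known", "first", "only" and "open" are said of these compounds alone.

Measured in a functional assay on PC-3 cells (Homo sapiens) for inhibition, read by sulforhodamine B assay; a higher number here means a weaker inhibitor of growth, a lower number a stronger inhibitor of growth:
- Compound 1 `c1ccc(-c2ccc(-c3ccc(-c4nc5ccccc5[nH]4)cc3)cc2)cc1`: 41200 nM
- Compound 2 `Cc1ccc2[nH]c(-c3ccc(-c4ccc(-c5cccc(Cl)c5)cc4)cc3)nc2c1`: 2670 nM
- Compound 3 `Oc1cccc2[nH]c(-c3ccc(-c4ccc(-c5ccccc5)cc4)cc3)nc12`: 1240 nM

Compound 3 has the lowest number of the three in this assay. Compound 4 `Oc1cccc2[nH]c(-c3ccc(-c4ccc(-c5ccc(OC(F)(F)F)cc5)cc4)cc3)nc12` differs from it in one place: trifluoromethoxy in place of hydrogen on an aromatic carbon, on an aromatic carbon of a six-membered aromatic ring of carbon only, para to a large group.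

For the measured compounds named here, the one measured step, a 33-fold lower number from compound 1 to compound 3 (1.52 log units; beyond the scatter), was large, but it swaps in hydroxy, a different group at a different place. Going by the values given here, no measured step places trifluoromethoxy, and the data give no firm direction. The expected outcome is therefore no change beyond the scatter, with a 1.0-fold lower number from compound 3 to compound 4 (0.01 log units; within the scatter) as the estimated step. For compound 4 the estimated value is 1200 nM, with an expected range of 400 nM to 3600 nM.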

Compound 4, concentration for 50% growth inhibition: 7410 nM
For compound 4 the middle estimate is 6.2-fold (0.79 log units) below the measured one; the measured number lies above the stated range.
By their numbers in this assay, from the lowest: compound 3; then compound 2; then compound 4; then compound 1.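

The position para to a large group, on the six-membered aromatic ring of carbon only, is not indifferent in this assay and responds to substitution. Trifluoromethoxy placed there gives a 6.0-fold higher number from compound 3 to compound 4 (0.78 log units; beyond the scatter) and so weakens growth inhibition, a change beyond the scatter that the earlier step, with hydroxy at a different place, could not reveal. Nothing measured here explains this rise.

A single group at this position cannot show a general trend. Going by these compounds, whether fluorine, methoxy, an amine or a carboxylic acid there would also raise the number remains open.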